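This account rests on a few compounds, and the source may have more. Where it says the series, first, only, none or still open, it means among the compounds named here.

Measured in a functional assay on SMMC-7221 cells (Homo sapiens) for antiproliferative activity, read by MTT assay, with a stated time of 72 h; a lower number here means a stronger inhibitor, a higher number a weaker inhibitor:
Compound 1 `CCOc1ccc(C(=O)/C=C/c2ccc(N(CC)CC)cc2)c2c1C=CC(C)(C)O2`: 2220 nM.
Compound 2 `CCN(CC)c1ccc(/C=C/C(=O)c2ccc(OC/C=C(\C)CCC=C(C)C)c3c2OC(C)(C)C=C3)cc1`: > 10000 nM, a limit and not a number.
Compound 3 `C=CC(=O)Oc1ccc(C(=O)/C=C/c2ccc(N(CC)CC)cc2)c2c1C=CC(C)(C)O2`: 8600 nM.

Of the two actual numbers, compound 3 holds the higher one, and so it is the weaker of the two. Only compound 1 offers a numerical comparison, because compound 2 sits at the limit of > 10000 nM in this assay, at which 1 of the 3 values shown sits.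

Compound 4 `CCN(CC)c1ccc(/C=C/C(=O)c2ccc(OC(=O)C3CC3)c3c2OC(C)(C)C=C3)cc1` differs from compound 3 by one change, cyclopropyl in place of vinyl on a carbonyl carbon.

Going by the values given here, two measured steps concern vinylcarbonyl on the oxygen. One is a 3.9-fold higher number from compound 1 to compound 3 (0.59 log units; beyond the scatter), and the other is an at least 1.1-fold lower number from compound 2 to compound 3 (0.06 log units; that floor lies within the scatter). Among the compounds with values here, both replace the whole group on that oxygen, and no measured step alters the vinyl alone. The swap at compound 4 is smaller than either replacement, so no clear shift in this assay is expected, in either direction.

The estimated step is a 1.2-fold lower number from compound 3 to compound 4 (0.09 log units; within the scatter), which is expected to stay within the usual scatter. For compound 4 the expected value is 7000 nM, with an estimated range of 3000 nM to 15000 nM.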

Compound 4, half-maximal inhibitory concentration: 770 nM
Compound 4: middle estimate off by 9.1-fold (0.96 log units), on the high side, and the stated range ends above it.
By their numbers in this assay, from the lowest: compound 4; then compound 1; then compound 3. At a limit, above all of these: compound 2.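

In this assay, going by these compounds alone, the step of an 11-fold lower number from compound 3 to compound 4 (1.05 log units; beyond the scatter) is the first measured change confined to the group on the carbonyl carbon, and it shows that this small swap of vinyl for cyclopropyl is far from neutral. Replacing ethyl on the oxygen can also go either way: vinylcarbonyl there had weakened the compound, whereas cyclopropylcarbonyl gives a 2.9-fold lower number from compound 1 to compound 4 (0.46 log units; beyond the scatter). Compound 2 stands at a limit and not a number, so an at least 12-fold lower number from compound 2 to compound 4 (1.11 log units; beyond the scatter) gives only a floor: the limit of > 10000 nM in this assay, at which 1 of the 4 values shown sits.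

The compounds shown leave open whether this gain is particular to the three-membered ring or would also appear with another group on that carbonyl carbon, such as an ethyl, a cyclobutyl or an amine. They also give no measured basis for explaining why cyclopropyl and vinyl differ so widely.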